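Shrinking the amine substituent on a shared core

A few compounds are considered here, and "the series" means these few. Any claim that something is new, unique, unknown or untested is made for them only; others in the source may bear on it.

Going by the values given here, compound 2 `CC1CCCN1c1ccc2cc(NC(=O)CCc3ccc(C(F)(F)F)cc3)ccc2n1` gives the lowest of the two numbers so far in a functional assay on HEK293 cells for activation of melanin-concentrating hormone receptor 1 (Rattus norvegicus), read by inositol phosphate accumulation (a higher number here means that more compound is needed for the effect, a lower number that less compound is needed), at 270 nM. Compound 1 `CN(c1ccc2cc(NC(=O)CCc3ccc(C(F)(F)F)cc3)ccc2n1)C1CCCCC1` gives 1200 nM in this assay, and the step of a 4.4-fold lower number from compound 1 to compound 2 (0.65 log units; beyond the scatter) shows how much a change of the amine at this position can move the number. Compound 3 `CN(C)c1ccc2cc(NC(=O)CCc3ccc(C(F)(F)F)cc3)ccc2n1` carries dimethylamino in place of 2-methylpyrrolidin-1-yl on an aromatic carbon. Among the compounds with values here, only that single step bears on this change, and it does not fix the direction, so a modest rise in the number is expected for compound 3, a 2.2-fold higher number from compound 2 to compound 3 (0.35 log units; beyond the scatter). Compound 3 is estimated at 600 nM, within a range from 150 nM to 2500 nM.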

Compound 3, half-maximal effective concentration: 110 nM
Estimate against measurement, compound 3: 5.5-fold (0.74 log units) above; the whole stated range lies above it.
By their numbers in this assay, from the lowest: compound 3; then compound 2; then compound 1.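

In this assay, replacing 2-methylpyrrolidin-1-yl with the open-chain dimethylamino gives a 2.5-fold lower number from compound 2 to compound 3 (0.39 log units; beyond the scatter) and so the ring on this nitrogen is not needed for the effect. Methyl in place of cyclohexyl on the same nitrogen gives an 11-fold lower number from compound 1 to compound 3 (1.04 log units; beyond the scatter) and this is the largest step among the three compounds. No evidence at hand explains either step. Still open, on these data alone, is whether methylamino or a plain amino group at this place would lower the number further. Diethylamino would show whether slightly longer chains on the nitrogen are tolerated.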